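A few compounds are considered here, and "the series" means these few. Any claim that something is new, unique, unknown or untested is made for them only; others in the source may bear on it.

Working notes on the series. Going by the values given here, in an ADME assay on MRC5 cells (Homo sapiens) for inhibition, with a stated time of 72 h (a lower number here means that less compound is needed, a higher number that more compound is needed for the effect), no compound has yet given a number. Compound 1, `COc1cccc(OC)c1C(=O)Nc1c[nH]nc1C(=O)NCc1ccccn1`, reports only the limit > 50000 nM. Compound 2, `COc1cccc(OC)c1C(=O)Nc1c[nH]nc1C(=O)NCCN1CCCC1`, also reports only the limit > 50000 nM. Compound 3, `COc1cccc(OC)c1C(=O)Nc1c[nH]nc1C(=O)NCCCOC(C)C`, likewise reports only the limit > 50000 nM. The whole picture so far is the limit of > 50000 nM in this assay, at which 3 of the 3 values shown sit, so compound 3 stands at that limit with no exact position of its own.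

Compound 4, `COc1cccc(OC)c1C(=O)Nc1c[nH]nc1C(=O)NCCCN(C)C`, is the next to be read. The change from compound 3 is dimethylamino in place of isopropoxy on a saturated chain carbon, three bonds along the chain from an amide-type nitrogen, turning 3-isopropoxypropyl into 3-(dimethylamino)propyl.

The nearest measured evidence is a step that the two limits leave unreadable from compound 2 to compound 3, which also exchanges a nitrogen-bearing group on the chain for isopropoxymethyl. Two further steps bear on it less directly: a step that the two limits leave unreadable from compound 1 to compound 2 and a step that the two limits leave unreadable from compound 1 to compound 3. None of the three has a readable size, so they set no magnitude and no direction for the new step. They show only that pyridin-2-yl, pyrrolidin-1-yl and isopropoxy side chains all leave the series at the limit.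

In this assay the expectation is therefore a number no higher from compound 3 to compound 4 (the limit leaves the size open), with no change beyond the scatter in either direction. Compound 4 is estimated at 50000 nM, with an expected range of 20000 nM to 100000 nM, and a further report at the limit is the likeliest outcome.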

Compound 4, half-maximal effective concentration: > 50000 nM
Compound 4 gave a limit, no number (the forecaster's own chance of this, stated with the estimate: 80%); the middle value lies on the limit itself.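

In this assay compound 4 gives > 50000 nM, a limit and not a number. Going by these compounds alone, no step from compound 1, compound 2 or compound 3 to compound 4 can be read. The compounds shown leave open how these side chains rank and how far the series lies from a measurable value, with every result so far at: the limit of > 50000 nM in this assay, at which 4 of the 4 values shown sit.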